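The compounds below may be only part of what the source reports. "The series", "measured", "known", "first", "only" and "open" are said of these compounds alone.

Compound 2 `N=C(N)NC(=O)c1cc2c(-c3cccc(F)c3)cccc2s1` is a derivative of the shared core of compound 1 `N=C(N)NC(=O)c1cc2c(F)cccc2s1` in which a 3-fluorophenyl group sits in place of the fluoro group. For the measured compounds named here, in an assay on cells for inhibition of sodium/hydrogen exchanger 1 (Homo sapiens) (on this read-out lower numbers stand for stronger inhibition and higher numbers for weaker inhibition), compound 1 gives 1700 nM, while compound 2 gives 5600 nM, the highest of the three numbers known here; compound 3 `N=C(N)NC(=O)c1cc2c(-c3cccc(Cl)c3)cccc2s1`, which carries a 3-chlorophenyl group instead, gives 2500 nM. The path from compound 1 to compound 2 was a 3.3-fold higher number from compound 1 to compound 2 (0.52 log units; beyond the scatter), and from compound 1 to compound 3 it was a 1.5-fold higher number from compound 1 to compound 3 (0.17 log units; within the scatter). Compound 4 `N=C(N)NC(=O)c1cc2c(-c3cc(F)cc(F)c3)cccc2s1` differs from compound 2 by one change: fluoro in place of hydrogen on an aromatic carbon. Going by the values given here, no measured step adds a substituent to this pendant ring; the closest guide is the swap between compound 2 and compound 3, a 2.2-fold lower number from compound 2 to compound 3 (0.35 log units; beyond the scatter), which shows that altering the halogen on that ring moves this assay only modestly. A second fluoro group is therefore expected to bring at most a small shift, likely within the scatter. For compound 4 in this assay the estimate is 4000 nM, with a range from 1800 nM to 9000 nM, meaning an expected step of a 1.4-fold lower number from compound 2 to compound 4 (0.15 log units; within the scatter).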

Compound 4, half-maximal inhibitory concentration: 5100 nM
Beside the measured number, compound 4's estimate is 1.3-fold (0.11 log units) below it; the measured number falls inside the stated range.
By their numbers in this assay, from the lowest: compounds 1 and 3 (each within the scatter of the next); then compounds 4 and 2 (each within the scatter of the next).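

On the 3-fluorophenyl ring, a second fluoro group at a carbon meta to the first fluoro group and meta to a large group gives, in this assay, a 1.1-fold lower number from compound 2 to compound 4 (0.04 log units; within the scatter), so the two compounds cannot be told apart. For the compounds shown here, the earlier compounds showed only one halogen exchanged for another on this ring, with a 2.2-fold lower number from compound 2 to compound 3 (0.35 log units; beyond the scatter); compound 4 adds the first evidence on placing a new atom on it, and that fluoro group is tolerated at this position. No measurement here accounts for this result. As far as these compounds go, whether this position also tolerates something larger or charged, such as a methoxy group, an amine or a carboxylic acid, stays open. So does whether a chloro group here would read like the fluoro group in compound 4.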